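The source may hold more compounds than are shown below. What is called first, only, known or untested is meant among the compounds shown, and "the series" means these compounds.

Measured compounds in a functional assay on MCF7 cells (Homo sapiens) for cytotoxicity, read by MTT assay, with a stated time of 72 h; a lower number here means a stronger inhibitor, a higher number a weaker inhibitor:

compound 1, `Cc1cc(=O)n(-c2ccc(F)cc2)nc1C(=O)Nc1ccc(Oc2ncnc3[nH]ccc23)c(F)c1`: 24500 nM
compound 2, `Cc1ccc(-n2nc(C(=O)Nc3ccc(Oc4ncnc5[nH]ccc45)c(F)c3)c(C)cc2=O)cc1`: 18900 nM
compound 3, `Cc1cc(=O)n(-c2ccc(Br)cc2F)nc1C(=O)Nc1ccc(Oc2ncnc3[nH]ccc23)c(F)c1`: 26600 nM

Where compound 3 stands: its number is not separated from either neighbour, since a 1.1-fold higher number from compound 1 to compound 3 (0.04 log units; within the scatter) and a 1.4-fold higher number from compound 2 to compound 3 (0.15 log units; within the scatter) are both within the scatter. Compound 1 and compound 2 likewise sit within the scatter of each other, a 1.3-fold lower number from compound 1 to compound 2 (0.11 log units; within the scatter). Across the three compounds this assay has so far shown no step that can be told from repeat noise.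

The next compound, compound 4, `Cc1cc(=O)n(-c2cccc(C(F)(F)F)c2)nc1C(=O)Nc1ccc(Oc2ncnc3[nH]ccc23)c(F)c1`, keeps the shared core of compound 3 and changes only the ring on the aromatic nitrogen: 3-(trifluoromethyl)phenyl in place of 4-bromo-2-fluorophenyl on an aromatic nitrogen.

Two of the measured steps bear on this position, both swapping the ring on the same aromatic nitrogen: a 1.1-fold higher number from compound 1 to compound 3 (0.04 log units; within the scatter) and a 1.4-fold higher number from compound 2 to compound 3 (0.15 log units; within the scatter). Each was within the scatter, whether the ring carried fluoro, methyl, or bromo with fluoro. The 3-(trifluoromethyl)phenyl ring has not been tried here, so the expectation rests on those two steps alone and is a flat one: no step beyond the scatter in either direction.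

Compound 4 is accordingly estimated at 24000 nM in this assay, with a range from 12000 nM to 48000 nM. The expected step is a 1.1-fold lower number from compound 3 to compound 4 (0.04 log units; within the scatter), that is, nothing resolvable.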

Compound 4, half-maximal inhibitory concentration: 11800 nM
For compound 4 the middle estimate is 2.0-fold (0.31 log units) above the measured one, and the stated range ends above it.
By their numbers in this assay, from the lowest: compounds 4, 2, 1 and 3 (each within the scatter of the next, the first and the last beyond it).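

In this assay the ring on the aromatic nitrogen now gives its first steps beyond the scatter, both modest and both toward a lower number with the 3-(trifluoromethyl)phenyl ring (a 2.3-fold lower number from compound 3 to compound 4 (0.35 log units; beyond the scatter); a 2.1-fold lower number from compound 1 to compound 4 (0.32 log units; beyond the scatter)). The position is therefore not wholly flat, though the response is small, and the step from the 4-methylphenyl ring stays within the scatter (a 1.6-fold lower number from compound 2 to compound 4 (0.20 log units; within the scatter)), so compound 2 cannot be told from compound 4 and the new ring cannot be said to outperform every ring shown. No measurement among those available accounts for the difference between these rings.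

Still open, on these data alone, is whether the steps belong to the trifluoromethyl group itself or to where it sits on the ring, since compound 4 differs from compound 1, compound 2 and compound 3 in both the group and its place. Also open, as far as these compounds go, is how the series would answer to a ring carrying an amine or a carboxylic acid, or to a saturated cyclohexyl ring on the same aromatic nitrogen.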